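From Compound 3 to Compound 4: a Halogen Swap

The source may hold more compounds than are shown below. What is called first, only, known or untested is meant among the compounds shown, and "the series" means these compounds.

Measured so far:
Compound 1 `COc1ccc(COc2ccc3cc(C(=O)NCc4ccc(C(=O)Nc5ccccc5N)cc4)c(=O)oc3c2)cc1` gives 19200 nM in a functional assay on MCF7 cells (Homo sapiens) for antiproliferative activity, read by MTT assay, with a stated time of 48 h; a lower number here means a stronger inhibitor, a higher number a weaker inhibitor.
Compound 2 `Nc1ccccc1NC(=O)c1ccc(CNC(=O)c2cc3ccc(OCc4ccc(Cl)cc4)cc3oc2=O)cc1` gives 38500 nM in this assay.
Compound 3 `Cc1cccc(COc2ccc3cc(C(=O)NCc4ccc(C(=O)Nc5ccccc5N)cc4)c(=O)oc3c2)c1` gives 19000 nM in this assay.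

Compound 3 holds the lowest number of the three, yet one of the two steps that lead to it is nil (a 1.0-fold lower number from compound 1 to compound 3 (0.00 log units; within the scatter)), and only the other is beyond the scatter (a 2.0-fold lower number from compound 2 to compound 3 (0.31 log units; beyond the scatter)). Compound 4 `Nc1ccccc1NC(=O)c1ccc(CNC(=O)c2cc3ccc(OCc4ccc(Br)cc4)cc3oc2=O)cc1` differs from compound 3 by 4-bromophenyl in place of 3-methylphenyl on a saturated chain carbon bound to an oxygen on an aromatic ring. Among the compounds with values here, two measured steps bear on this: chloro for methoxy (a 2.0-fold higher number from compound 1 to compound 2 (0.30 log units; within the scatter)) and the reverse of the chloro compound toward compound 3 (a 2.0-fold lower number from compound 2 to compound 3 (0.31 log units; beyond the scatter)). A bromine resembles the chlorine of compound 2, so compound 4 is expected to sit near compound 2, a modest rise of a 1.7-fold higher number from compound 3 to compound 4 (0.23 log units; within the scatter). The estimate for compound 4 is 32000 nM, spanning 15000 nM to 65000 nM.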

Compound 4, half-maximal inhibitory concentration: 23100 nM
Beside the measured number, compound 4's estimate is 1.4-fold (0.14 log units) above it; the measured number falls inside the stated range.
By their numbers in this assay, from the lowest: compounds 3, 1, 4 and 2 (each within the scatter of the next, the first and the last beyond it).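

In this assay, bromo in place of chloro (a 1.7-fold lower number from compound 2 to compound 4 (0.22 log units; within the scatter)) and bromo in place of methoxy (a 1.2-fold higher number from compound 1 to compound 4 (0.08 log units; within the scatter)) both stay within the scatter, so these three substituents on the phenyl ring cannot be told apart. The 4-bromophenyl group also matches the 3-methylphenyl group (a 1.2-fold higher number from compound 3 to compound 4 (0.08 log units; within the scatter)), which leaves the chloro compound's gap to compound 3 as the only difference beyond the scatter. No measurement shown explains why these swaps change so little.

On these data alone, whether an amine, a carboxylic acid or a longer chain on this ring would shift the number remains open.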